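This account rests on a few compounds, and the source may have more. Where it says the series, first, only, none or still open, it means among the compounds named here.

Measured so far:
compound 1 `NC(=O)CN(CCC(c1ccccc1)c1ccccc1)C(=O)CN(CCC(c1ccccc1)c1ccccc1)C(=O)CNCC1CCCO1` gives 2570 nM in an ADME assay on A549 cells (Homo sapiens) for cytotoxicity, with a stated time of 72 h; a lower number here means a stronger inhibitor of growth, a higher number a weaker inhibitor of growth;
compound 2 `NC(=O)CN(CCC(c1ccccc1)c1ccccc1)C(=O)CNCCC(c1ccccc1)c1ccccc1` gives 3080 nM in this assay.

Compound 2 and compound 1 thus sit together: the step of a 1.2-fold higher number from compound 1 to compound 2 (0.08 log units; within the scatter) shows that removing a whole side arm from an amine nitrogen left the number essentially where it was. Compound 3 `O=C(CNCCC(c1ccccc1)c1ccccc1)NCCC(c1ccccc1)c1ccccc1` has not yet been measured. It differs from compound 2 by hydrogen in place of carbamoylmethyl on an amide-type nitrogen, so once again a piece is taken off a nitrogen and replaced by hydrogen, leaving the two diphenylpropyl arms of the shared core untouched. For the measured compounds named here, the only step that bears on this is the one from compound 1 to compound 2, which was small. The expectation is therefore a change of at most similar size in this assay, with no clear direction beyond the scatter. Compound 3 is accordingly estimated at 3500 nM, with a plausible range from 1200 nM to 10000 nM. This estimate corresponds to an expected step of a 1.1-fold higher number from compound 2 to compound 3 (0.06 log units; within the scatter).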

Compound 3, concentration for 50% growth inhibition: 3460 nM
Beside the measured number, compound 3's estimate is 1.0-fold (0.00 log units) above it; low and high end bracket the measured number.
By their numbers in this assay, from the lowest: compounds 1, 2 and 3 (each within the scatter of the next).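

Measured in this assay the replacement of carbamoylmethyl by hydrogen on the amide-type nitrogen gives a 1.1-fold higher number from compound 2 to compound 3 (0.05 log units; within the scatter) and so shows that this nitrogen, like the amine nitrogen of the earlier step, can lose its group while the two numbers stay within the scatter of each other. The group that leaves holds a hydrogen-bond donor and a hydrogen-bond acceptor, and compound 3 shows that this reading does not depend on keeping that carbamoylmethyl group. No measurement at hand gives a reason for this result.

Still open, as far as these compounds go, is whether a different group on this nitrogen, such as a methyl, an amine or a longer chain ending in a carboxylic acid, would move the number beyond the scatter. From the compounds shown here alone, the diphenylpropyl arms are present throughout, so what happens when one of them gives way to a shorter chain also remains unknown.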